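The source may hold more compounds than are shown below. What is called first, only, known or untested is meant among the compounds shown, and "the series" means these compounds.

Among the compounds measured here, compound 3 `O=C(c1ccccc1F)N1CC(c2nc(-c3cccc(Cl)c3)no2)C1` is the one that gives an actual number in an assay on HEK293 cells for negative allosteric modulation of metabotropic glutamate receptor 5 (Homo sapiens), read by FLIPR (on this read-out higher numbers stand for weaker inhibition and lower numbers for stronger inhibition), where compound 3 reaches 670 nM. Compound 1 `O=C(C1CCC2(CCC2)CC1)N1CC(c2nc(-c3cccc(Cl)c3)no2)C1` gives only a limit of the assay, > 10000 nM. Compound 2 `O=C(N1CCC(F)CC1)N1CC(c2nc(-c3cccc(Cl)c3)no2)C1` likewise gives only a limit, > 10000 nM. The steps of an at least 14-fold lower number from compound 1 to compound 3 (1.17 log units; beyond the scatter) and an at least 14-fold lower number from compound 2 to compound 3 (1.17 log units; beyond the scatter) therefore show that a fluorophenyl group on the carbonyl carbon is a clear gain over the saturated rings, while the step that the two limits leave unreadable from compound 1 to compound 2 cannot be read because both values sit at the limit of > 10000 nM in this assay, at which 2 of the 3 values shown sit. Compound 4 `O=C(c1ccc(F)cc1)N1CC(c2nc(-c3cccc(Cl)c3)no2)C1` keeps that fluorophenyl group but differs by 4-fluorophenyl in place of 2-fluorophenyl on a carbonyl carbon. Among the compounds with values here, none of the measured steps moves the fluorine around the aromatic ring, so no direct guide exists; a change of moderate size in either direction is expected, estimated as a 1.3-fold higher number from compound 3 to compound 4 (0.13 log units; within the scatter). Compound 4 is thus expected to give about 900 nM, within a range from 250 nM to 3500 nM.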

Compound 4, half-maximal inhibitory concentration: 4000 nM
For compound 4 the middle estimate is 4.4-fold (0.65 log units) below the measured one; the measured number lies above the stated range.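

In this assay, within the data shown here, where the fluorine sits on the ring matters, a point no earlier step could show: a 6.0-fold higher number from compound 3 to compound 4 (0.78 log units; beyond the scatter) favours 2-fluorophenyl over 4-fluorophenyl on the carbonyl carbon. Even so, 4-fluorophenyl keeps a gain over the saturated groups, with an at least 2.5-fold lower number from compound 2 to compound 4 (0.39 log units; beyond the scatter) and an at least 2.5-fold lower number from compound 1 to compound 4 (0.39 log units; beyond the scatter). These last two steps give only a minimum size, because compound 1 and compound 2 each stand at a limit of the assay: the limit of > 10000 nM in this assay, at which 2 of the 4 values shown sit.

The compounds shown give no cause for the difference between the two fluorophenyl groups. Going by these compounds, how plain phenyl, 2-chlorophenyl or 2-methoxyphenyl would compare on the same carbonyl carbon remains open.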